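Methoxy Step Repeated on a Hydroxamic Acid Sulfonamide Series

A few compounds are considered here, and "the series" means these few. Any claim that something is new, unique, unknown or untested is made for them only; others in the source may bear on it.

Measured compounds:
compound 1 `Cc1cc2cc(NS(=O)(=O)Cc3ccc(C(=O)NO)cc3)ccc2n(C)c1=O` 8%
compound 2 `COc1ccc(C(=O)NO)cc1CS(=O)(=O)Nc1ccc2c(c1)cc(C)c(=O)n2C` 0%
compound 3 `Cc1cc2cc(NS(=O)(=O)Cc3cccc(C(=O)NO)c3)ccc2n(C)c1=O` 0%

In a functional assay on THP-1 cells (Homo sapiens) for antiproliferative activity, tested at 20 uM (a lower number here means a weaker effect, a higher number a stronger effect of the compound at the concentration tested), compound 1 gives 8%, compound 2 gives 0% and compound 3 gives 0%; all three lie within the scatter of one another. Compound 3 and compound 2 differ by methoxy in place of hydrogen on an aromatic carbon, and this step is no change at the digits printed from compound 3 to compound 2 (within the scatter). The difference between the core of compound 1 and the core of compound 3 is not broken down here. Compound 4 `COc1cc(C(=O)NO)ccc1CS(=O)(=O)Nc1ccc2c(c1)cc(C)c(=O)n2C` differs from compound 1 by methoxy in place of hydrogen on an aromatic carbon. This is the same kind of change, not the same one: in compound 2 the methoxy stands para to a hydroxycarbamoyl group, in compound 4 meta to it. Because no change at the digits printed from compound 3 to compound 2 (within the scatter), the step of a number 3 percentage points lower from compound 1 to compound 4 (within the scatter) is expected to be small as well. Compound 4 is therefore estimated at 5%, between 0% and 15%.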

Compound 4, a percentage reported as inhibition, at one concentration (the size of the read-out at that concentration, not a potency): 0%
Compound 4: middle estimate off by 5 percentage points, on the high side; measured number inside the range.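

Methoxy in place of hydrogen on an aromatic carbon of the core of compound 1 gives a number 8 percentage points lower from compound 1 to compound 4 (within the scatter) in this assay. Set beside the earlier step, the change reads alike on the two cores: the same change on two cores in this assay, no change at the digits printed (within the scatter) from compound 3 to compound 2 and a number 8 percentage points lower (within the scatter) from compound 1 to compound 4, 8 percentage points apart, within the scatter of two such steps

Going by these compounds alone, this shows only that the step stays within the scatter on both cores; it does not show that methoxy can be carried over freely, as it stands in a different place in each pair, and compound 3 at 0% and compound 1 at 8% offer no starting values that lie beyond the scatter of each other.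

The compounds shown leave open whether an amine or a longer alkoxy chain in place of methoxy would move the read-out beyond the scatter. They also leave open what a carboxylic acid in place of the hydroxycarbamoyl group would do.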